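A few compounds are considered here, and "the series" means these few. Any claim that something is new, unique, unknown or untested is made for them only; others in the source may bear on it.

Working notes on the series. Compound 1, `CCOc1ccc2c(=O)cc(CC)oc2c1CBr`, was run in a functional assay on DU-145 cells (Homo sapiens) for antiproliferative activity, read by sulforhodamine B assay, with a stated time of 72 h; a lower number here means a stronger inhibitor of growth, a higher number a weaker inhibitor of growth; compound 1 reaches only the limit of the assay, > 32100 nM, which is not a number. Compound 2, `COc1ccc2c(=O)cc(C(C)Br)oc2c1CBr`, in this assay likewise gives only a limit, > 26500 nM, again not a number. Going by the values given here, compound 2 therefore stands at a limit, and so does the other measured compound (the limit of > 26500 nM in this assay, at which 1 of the 2 values shown sits, (the limit of > 32100 nM in this assay, at which 1 of the 2 values shown sits)); with no number on either side, no step between the two measured compounds can be sized.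

Compound 3, `CCOc1ccc2c(=O)cc(C(C)Br)oc2c1CBr`, remains to be measured. It differs from compound 2 by methyl in place of hydrogen on a saturated chain carbon bound to an oxygen on an aromatic ring. The ethoxy group is already present in compound 1, which sits at > 32100 nM, and the one-carbon-longer side chain bearing bromine is present in compound 2, which sits at > 26500 nM; compound 3 combines both. In this assay no step beyond the scatter is expected for compound 3, most likely another limit. The expected step from compound 2 is a step that the limit leaves unreadable from compound 2 to compound 3. Compound 3 is estimated at 40000 nM, within 15000 nM to 150000 nM.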

Compound 3, concentration for 50% growth inhibition: 20900 nM
Compound 3: the middle estimate sits 1.9-fold (0.28 log units) above what was measured, within the range that was stated.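

Going by these compounds alone, compound 3 gives the first number of the series in this assay, so the methyl in place of hydrogen on a saturated chain carbon bound to an oxygen on an aromatic ring now has a floor: an at least 1.2-fold lower number from compound 2 to compound 3 (0.10 log units; that floor lies within the scatter). The bromo in place of hydrogen on a saturated chain carbon bound to an aromatic carbon and a saturated chain carbon likewise has a floor: an at least 1.5-fold lower number from compound 1 to compound 3 (0.18 log units; that floor lies within the scatter). Among the compounds shown, only compound 3 carries both the ethoxy group and the bromine-bearing side chain and gives a number, but neither floor shows a change beyond the scatter.

The full size of both steps cannot be read, as compound 1 and compound 2 stand at limits. On these data alone, whether a propoxy group in place of ethoxy, or an amine in place of the side-chain bromine, would shift the number beyond the scatter remains open.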